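Oxazolidinone series: carbamate to difluoroacetamide, lipophilicity

The source may report more compounds than this note shows. Statements on the series, on what has been measured and on what is new or still open speak of the compounds shown alone.

Measured so far:
compound 1 `O=C1CCC(=O)N1C[C@H]1CN(c2ccc(-n3cc(-c4ccccn4)cn3)c(F)c2)C(=O)O1`: 1.58
compound 2 `COC(=O)NC[C@H]1CN(c2ccc(-n3cc(-c4ccccn4)cn3)c(F)c2)C(=O)O1`: 2.03

In a physicochemical assay for lipophilicity, read by HPLC, measured as octanol-water partition (a higher number here means a more lipophilic compound, a lower number a more polar compound), compound 2 sits at the higher of the two values, with compound 1 standing a number 0.45 log units higher from compound 1 to compound 2 (beyond the scatter) apart. Going by the values given here, compound 3 `O=C(NC[C@H]1CN(c2ccc(-n3cc(-c4ccccn4)cn3)c(F)c2)C(=O)O1)C(F)F` carries difluoromethyl in place of methoxy on a carbonyl carbon, a change at the carbonyl carbon rather than at the chain carbon where the one measured step was taken, so that step only frames the scale. For compound 3 the expected result is a small rise, a number 0.22 log units higher from compound 2 to compound 3 (within the scatter), close to the scatter. The estimate for compound 3 is 2.25, between 1.85 and 2.65.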

Compound 3, partition coefficient: 1.9
For compound 3 the middle estimate is 0.35 log units above the measured one; the range from low to high includes it.
By their numbers in this assay, from the lowest: compound 1; then compounds 3 and 2 (each within the scatter of the next).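

In this assay, difluoromethyl in place of methoxy on the carbonyl carbon leaves the two compounds within the scatter (a number 0.13 log units lower from compound 2 to compound 3 (within the scatter)), so this read-out does not separate the two groups at this position. The ((difluoromethyl)carbonyl)amino group also stands clear of 2,5-dioxopyrrolidin-1-yl on the chain carbon (a number 0.32 log units higher from compound 1 to compound 3 (beyond the scatter)), as the (methoxycarbonyl)amino group does. No measured evidence here bears on the reason for these results.

Still open, on these data alone, is whether a longer chain or an amine on this carbonyl carbon would move the number beyond the scatter.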